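This account rests on a few compounds, and the source may have more. Where it says the series, first, only, none or still open, it means among the compounds named here.

Compound 2 `Cc1cc(-c2c(F)cc3c(=O)c(Cc4ccc(Cl)cc4)cn(C4CC4)c3c2F)cc(C)n1` gives 20000 nM in a functional assay on P388 cells (Mus musculus) for cytotoxicity (on this read-out lower numbers stand for stronger inhibition and higher numbers for weaker inhibition), the highest of the three numbers measured: compound 1 `Cc1cc(-c2c(F)cc3c(=O)c(Cc4ccccc4N)cn(C4CC4)c3c2F)cc(C)n1` gives 2100 nM in this assay, and compound 3 `Cc1cc(-c2c(F)cc3c(=O)c(Cc4c(O)cc(O)cc4O)cn(C4CC4)c3c2F)cc(C)n1` gives 470 nM. Compound 4 `Cc1cc(-c2c(F)cc3c(=O)c(Cc4ccccc4)cn(C4CC4)c3c2F)cc(C)n1` has not yet been measured; it differs from compound 2 by hydrogen in place of chloro on an aromatic carbon. For the measured compounds named here, no measured step removes only the chloro. The nearest comparisons exchange the whole aryl group, with a 9.5-fold higher number from compound 1 to compound 2 (0.98 log units; beyond the scatter) and a 43-fold lower number from compound 2 to compound 3 (1.63 log units; beyond the scatter), so that both other aryl groups show lower numbers than 4-chlorophenyl. As the present change is smaller than either of those, a modest decrease is expected in this assay, a 2.5-fold lower number from compound 2 to compound 4 (0.40 log units; beyond the scatter). Compound 4 is therefore estimated at 8000 nM, with a range from 3000 nM to 25000 nM.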

Compound 4, half-maximal inhibitory concentration: 7300 nM
Compound 4: middle estimate off by 1.1-fold (0.04 log units), on the high side, within the range that was stated.
By their numbers in this assay, from the lowest: compound 3; then compound 1; then compound 4; then compound 2.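

In this assay the chloro can now be read on its own, with a 2.7-fold lower number from compound 2 to compound 4 (0.44 log units; beyond the scatter) on its removal. Compound 4 also gives the other aryl groups an unsubstituted reference: replacing the amino with hydrogen gives a 3.5-fold higher number from compound 1 to compound 4 (0.54 log units; beyond the scatter), and phenyl in place of 2,4,6-trihydroxyphenyl gives a 16-fold higher number from compound 3 to compound 4 (1.19 log units; beyond the scatter), so that against phenyl only the 4-chlorophenyl of compound 2 has the higher number, while compound 1 and compound 3 have lower numbers. No evidence is available to explain these differences. On these data alone, how a single hydroxyl, a methoxy or a carboxylic acid on the phenyl ring would read remains open, as does a longer chain in place of the benzyl link.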